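From ethoxycarbonyl to carboxy in compound 4

The source may report more compounds than this note shows. Statements on the series, on what has been measured and on what is new or still open speak of the compounds shown alone.

In a functional assay on MCF7 cells (Homo sapiens) for inhibition (on this read-out higher numbers stand for weaker inhibition and lower numbers for stronger inhibition), compound 1 `C/C=C/C(C)=C/[C@@]1(C)SC(O)=CC1=O` gives 17.3 ug/mL and compound 2 `CCCCCC[C@@]1(C)SC(=O)C=C1OCC(=O)OCC` gives 14.2 ug/mL while compound 3 `CCCCCCCC[C@@]1(C)SC(=O)C=C1OCC(=O)OCC` gives 10.8 ug/mL on the same read-out. All three values lie within the scatter of one another, so compound 3 stands together with the other two rather than apart from them. Compound 4 `CCCCCCCC[C@@]1(C)SC(=O)C=C1OCC(=O)O` differs from compound 3 in one place, with hydrogen in place of ethyl on an oxygen next to a carbonyl group, so that ethoxycarbonyl becomes carboxy: hydrogen in place of ethyl on an oxygen next to a carbonyl group is the full count of that difference. Among the measured compounds shown here, the only measured step between close relatives is a 1.3-fold lower number from compound 2 to compound 3 (0.12 log units; within the scatter) and it concerns a saturated chain carbon, not this oxygen. For the measured compounds named here, it therefore bears on the new change only loosely, and no measured pair shows what a change at this oxygen does. With no direction supported by the data, no step beyond the scatter is expected in this assay for now, though the uncertainty is wide. The expected step is a 1.2-fold higher number from compound 3 to compound 4 (0.08 log units; within the scatter) on this estimate. The estimate for compound 4 is 13 ug/mL with an expected range from 5 ug/mL to 35 ug/mL around it.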

Compound 4, half-maximal inhibitory concentration: 13.8 ug/mL
Compound 4: the middle estimate sits 1.1-fold (0.03 log units) below what was measured; measured number inside the range.
By their numbers in this assay, from the lowest: compounds 3, 4, 2 and 1 (each within the scatter of the next).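

Among the compounds shown here, the step at this oxygen is the first measured one there: hydrogen in place of ethyl, turning ethoxycarbonyl into carboxy, gives in this assay a 1.3-fold higher number from compound 3 to compound 4 (0.11 log units; within the scatter). For the compounds shown here, the ethyl group of the ester is thus not needed to keep the reading in the range of the earlier compounds, and the free carboxy group and its ester cannot be told apart on this read-out; together with a 1.3-fold lower number from compound 2 to compound 3 (0.12 log units; within the scatter), this means that neither of the two single changes measured so far, one on the saturated chain and one on this oxygen, has moved the number beyond the scatter. No measurement of any property of these compounds bears on this result, so it stands without an explanation.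

The compounds shown leave open whether any group at this place can separate itself from the scatter in this assay, for instance a primary amide or a tetrazole in place of carboxy, or a benzyl group in place of ethyl on the oxygen. They also leave open whether a longer chain on the carboxy compound would give a number that differs from that of compound 4, which stands at 13.8 ug/mL.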